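The compounds below may be only part of what the source reports. "The series", "measured", "known", "first", "only" and "open" are said of these compounds alone.

In a toxicity assay on Huh-7.5 cells (Homo sapiens) for inhibition, read by MTT assay, with a stated time of 96 h (on this read-out higher numbers stand for lower toxicity in this test and lower numbers for higher toxicity in this test), compound 1 `CN1CCN(Cc2ccc(NC(=O)c3ccc(OCCCCl)c(N)c3)cc2C(F)(F)F)CC1` gives 12900 nM, the lowest of the three numbers at hand. Compound 3 `CC(C)Oc1ccc(C(=O)Nc2ccc(N(C)C)cc2)cc1[N+](=O)[O-]` gives 50000 nM, and compound 2 `COc1ccc(NC(=O)c2ccc(OCCCN(C)C)c([N+](=O)[O-])c2)cc1` gives 127000 nM; both lie beyond the usual scatter above compound 1. Compound 4 `CN1CCN(Cc2ccc(NC(=O)c3ccc(OCCCCl)c(Cl)c3)cc2C(F)(F)F)CC1` has not yet been tested in this assay. It differs from compound 1 in one place: chloro in place of amino on an aromatic carbon. Within the data shown here, no step between measured compounds tells how such a change moves this number, so the expectation rests on compound 1 alone, and only a small step is expected, within or barely beyond the scatter, if anything toward a lower number. The estimate for compound 4 in this assay is 10000 nM, with a range from 4000 nM to 25000 nM. That corresponds to an expected step of a 1.3-fold lower number from compound 1 to compound 4 (0.11 log units; within the scatter).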

Compound 4, half-maximal cytotoxic concentration: 4100 nM
Compound 4: the middle estimate sits 2.4-fold (0.39 log units) above what was measured, and the stated range covers the measured number.
By their numbers in this assay, from the lowest: compound 4; then compound 1; then compound 3; then compound 2.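

On the aromatic carbon ortho to the 3-chloropropoxy group, chloro in place of amino gives a 3.1-fold lower number from compound 1 to compound 4 (0.50 log units; beyond the scatter) in this assay. Among these compounds, this is the first single change that can be read here, and it shows that toxicity in this test responds to what this position carries, with the step beyond the scatter. Nothing at hand explains why the number moves. Going by these compounds, whether fluoro or methyl at this position would behave like chloro or like amino remains open. So does whether this change would act the same way on another core.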